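A methyl on the anilino ring of compound 1

A few compounds are considered here, and "the series" means these few. Any claim that something is new, unique, unknown or untested is made for them only; others in the source may bear on it.

Compound 1 `C=CC(=O)Nc1cccc(NC(=O)CSc2nc(Nc3ccccc3)c3ccccc3n2)c1` gives 8740 nM in a functional assay on PC-3 cells (Homo sapiens) for inhibition, read by MTT assay, with a stated time of 72 h (on this read-out higher numbers stand for weaker inhibition and lower numbers for stronger inhibition), the lowest of the three numbers shown, though compound 2 `O=C(CSc1nc(Nc2ccccc2)c2ccccc2n1)Nc1ccc(C(F)(F)F)cc1` with 10400 nM and compound 3 `O=C(CSc1nc(Nc2ccccc2)c2ccccc2n1)Nc1ccc(Cl)cc1Cl` with 9110 nM both lie within the scatter of it, as a 1.2-fold higher number from compound 1 to compound 2 (0.08 log units; within the scatter) and a 1.0-fold higher number from compound 1 to compound 3 (0.02 log units; within the scatter) show. Compound 4 `C=CC(=O)Nc1cccc(NC(=O)CSc2nc(Nc3cccc(C)c3)c3ccccc3n2)c1` differs from compound 1 by methyl in place of hydrogen on an aromatic carbon, read one bond further out as anilino to (3-methylphenyl)amino. For the measured compounds named here, none of the measured steps touches this anilino group: all three, including a 1.1-fold lower number from compound 2 to compound 3 (0.06 log units; within the scatter), alter only the aryl on the amide-type nitrogen, and all stay within the scatter. With no measured guide for this position, no step beyond the scatter is expected, so compound 4 is estimated at 8500 nM (range 3000 nM to 25000 nM), an expected step of a 1.0-fold lower number from compound 1 to compound 4 (0.01 log units; within the scatter).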

Compound 4, half-maximal inhibitory concentration: 29200 nM
Compound 4: middle estimate off by 3.4-fold (0.54 log units), on the low side; measured number outside the range, above it.
By their numbers in this assay, from the lowest: compounds 1, 3 and 2 (each within the scatter of the next); then compound 4.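

In this assay, the anilino ring of the shared core responds to a small change: methyl in place of hydrogen, one heavy atom meta to a large group, gives a 3.3-fold higher number from compound 1 to compound 4 (0.52 log units; beyond the scatter) and so moves the number beyond the scatter, whereas every listed change to the aryl on the amide-type nitrogen stayed within it. Nothing available explains this step. Open, as far as these compounds go, is whether a fluorine or a methoxy group at this place would give a similar step, and whether methyl would do so alongside the 4-(trifluoromethyl)phenyl or 2,4-dichlorophenyl group.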